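The source may report more compounds than this note shows. Statements on the series, on what has been measured and on what is new or still open speak of the compounds shown alone.

Working notes on the series.

Three measured compounds share the core seen in compound 1 `Oc1ccc(/C=C/c2ccccc2O)cc1`. In an ADME assay on HEK293 cells (Homo sapiens) for inhibition, read by MTT assay, with a stated time of 2 days (a higher number here means a weaker inhibitor, a lower number a stronger inhibitor), compound 1 gives 17.5 ug/mL. Compound 2 `Nc1ccccc1/C=C/c1ccccc1O` gives 27 ug/mL in this assay, and compound 3 `Nc1ccccc1/C=C/c1cccc(O)c1` gives 20 ug/mL. Compound 1 carries the lowest of the three numbers, but its gap to compound 3 and its gap to compound 2 both lie within the usual scatter of repeated measurements, so no order among the three can be read from these values. For the measured compounds named here, no pair of measured compounds differs in a single place, so no measured single-change step is available.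

Compound 4 `Nc1ccccc1/C=C/c1ccc(O)cc1` has not yet been measured. It differs from compound 1 by amino in place of hydroxy on an aromatic carbon. Compound 2 and compound 3 already carry one amino group and one hydroxy group each, and their values sit within the scatter of compound 1, which gives no sign that the amino group by itself moves the number. For compound 4 the step of a 1.1-fold higher number from compound 1 to compound 4 (0.06 log units; within the scatter) is therefore expected to be no larger than the scatter, in either direction. Compound 4 is estimated at 20 ug/mL, with a range from 10 ug/mL to 40 ug/mL.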

Compound 4, half-maximal inhibitory concentration: 7 ug/mL
Estimate against measurement, compound 4: 2.9-fold (0.46 log units) above, and the stated range ends above it.
By their numbers in this assay, from the lowest: compound 4; then compounds 1, 3 and 2 (each within the scatter of the next).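

For the compounds shown here, the swap of hydroxy for amino on an aromatic carbon, ortho to a group of 9 heavy atoms, gives the first measured single-change step: in this assay there is a 2.5-fold lower number from compound 1 to compound 4 (0.40 log units; beyond the scatter), a modest move towards stronger inhibition that compound 2 and compound 3 could not reveal. The swap leaves the heavy-atom count, the hydrogen-bond donor and acceptor counts and the net charge as they were, so these counts do not separate the two compounds, and at this position the identity of the group itself goes with a difference in the number. Nothing measured here accounts for the step, so it stands as an observation without an explanation.

This is a single step at a single position, so it remains open whether the same swap would move the number at the other hydroxy group of compound 1, where no matching pair is shown. On these data alone, it also remains open how other groups at this position would read, such as a methoxy group, a methylamino group or a carboxylic acid.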